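The source may hold more compounds than are shown below. What is called first, only, known or untested is meant among the compounds shown, and "the series" means these compounds.

In an ADME assay on T29 cells (Homo sapiens) for cytotoxicity, read by sulforhodamine B assay, with a stated time of 3 days (a lower number here means a stronger inhibitor, a higher number a weaker inhibitor), compound 1 `OCc1cn(Cc2ccccc2)c2ccccc12` gives 14500 nM. Compound 2 `Cc1ccc(Cn2cc(CO)c3ccccc32)cc1` differs from compound 1 by methyl in place of hydrogen on an aromatic carbon. In this assay compound 2 gives > 31600 nM, which is a limit of the assay and not a number. This is the limit of > 31600 nM in this assay, at which 1 of the 2 values shown sits. The step of an at least 2.1-fold higher number from compound 1 to compound 2 (0.33 log units; beyond the scatter) thus shows compound 2 as the weaker inhibitor of the two, by a margin whose true size is not known, since only a limit stands for it. Compound 3 `COc1ccc(Cn2cc(CO)c3ccccc32)cc1` has not yet been measured; it differs from compound 2 by methoxy in place of methyl on an aromatic carbon. Among the compounds with values here, no measured step swaps methyl for methoxy, so the one step measured so far is the only guide, and it moved the number out of the measurable range. A change in the same spot is expected to leave compound 3 near that limit, with a real chance that the assay again reports only a limit. Compound 3 is therefore estimated at 31600 nM, with a range from 10000 nM to 100000 nM. That estimate means an expected step of a number no higher from compound 2 to compound 3 (the limit leaves the size open).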

Compound 3, half-maximal inhibitory concentration: > 31600 nM
Compound 3: no number, only a limit; the forecaster's own chance of this, stated with the estimate: 55%; the middle value lies on the limit itself.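

Compound 3 shows that methoxy, like methyl before it, can sit on the six-membered aromatic ring of carbon only, para to a large group, and still leave this assay without a measured number: compound 3 gives > 31600 nM, which is a limit of the assay and not a number. Replacing hydrogen with methoxy brings an at least 2.1-fold higher number from compound 1 to compound 3 (0.33 log units; beyond the scatter), so among the compounds shown the move to a weaker inhibitor at this position is not confined to methyl but also occurs with a group that contains oxygen. The direct step from methyl to methoxy cannot be read, and neither compound 2 nor compound 3 can be called the weaker, because both stop at the same ceiling: the limit of > 31600 nM in this assay, at which 2 of the 3 values shown sit.

As far as these compounds go, how far the true values of compound 2 and compound 3 lie beyond that limit remains open, so the size of each group's effect is still unknown. Also open, from the compounds shown here alone, is whether a fluorine atom, an amine or a carboxylic acid in the same spot would keep the number out of range or bring it back toward that of compound 1.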